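The compounds below may be only part of what the source reports. "The series", "measured", "known", "first", "only" and "open" are said of these compounds alone.

In a functional assay (Nicotiana tabacum) (on this read-out higher numbers stand for weaker inhibition and lower numbers for stronger inhibition), three compounds sharing one core have been measured: compound 1 `CCCCNc1nc(SC)nc2ncccc12` gives 270 nM, compound 2 `CCCCCCCNc1nc(SC)nc2ncccc12` gives 4070 nM, and compound 3 `C=CCNc1nc(SC)nc2ncccc12` gives 400 nM. Compound 3 stands level with compound 1 within the scatter, and far below compound 2 on these numbers. Compound 4 `CSc1nc(NCc2ccccc2)c2cccnc2n1` differs from compound 3 by one change: phenyl in place of vinyl on a saturated chain carbon bound to a nitrogen on an aromatic ring.

Within the data shown here, three measured steps bear on this place. The step of a 1.5-fold higher number from compound 1 to compound 3 (0.17 log units; within the scatter) was small, while a 15-fold higher number from compound 1 to compound 2 (1.18 log units; beyond the scatter) and a 10-fold lower number from compound 2 to compound 3 (1.01 log units; beyond the scatter) were large, and both of those large steps involve compound 2. Among the measured compounds shown here, none of the three brings in a ring, so the data offer no direct precedent for phenyl. A step beyond the scatter in this assay is therefore not expected, though a slightly higher number is thought likely. The estimated step is a 1.4-fold higher number from compound 3 to compound 4 (0.14 log units; within the scatter). Compound 4 is expected at 550 nM, within an estimated range of 150 nM to 2000 nM.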

Compound 4, half-maximal inhibitory concentration: 25200 nM
For compound 4 the middle estimate is 46-fold (1.66 log units) below the measured one; measured number outside the range, above it.
By their numbers in this assay, from the lowest: compounds 1 and 3 (each within the scatter of the next); then compound 2; then compound 4.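

In this assay, phenyl on a saturated chain carbon bound to a nitrogen on an aromatic ring gives a far higher number than either of the shorter groups, with a 63-fold higher number from compound 3 to compound 4 (1.80 log units; beyond the scatter) and a 93-fold higher number from compound 1 to compound 4 (1.97 log units; beyond the scatter) on the same read-out. Vinyl and propyl had stood within the scatter of each other at this place, so the earlier compounds gave no sign that this change could move the number so far. Phenyl also exceeds hexyl, the highest of the earlier groups, with a 6.2-fold higher number from compound 2 to compound 4 (0.79 log units; beyond the scatter) in this comparison. No measurement given here accounts for these rises.

The compounds shown leave open whether the rise belongs to an aromatic ring or to any ring, which cyclohexyl at this place would separate. They also leave open whether pyridyl or methoxyphenyl would follow phenyl.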